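The source may hold more compounds than are shown below. What is called first, only, known or untested is meant among the compounds shown, and "the series" means these compounds.

Measured so far:
Compound 1 `CC(C)(C)N(NC(=O)c1ccccc1Cl)C(=O)c1ccccc1Cl` gives 331 nM in an assay on cells for agonist activity at ecdysone receptor (Bombyx mori), read by a luciferase reporter, with a stated time of 24 h; on this read-out higher numbers stand for an effect only at larger amounts of compound and lower numbers for an effect already at smaller amounts.
Compound 2 `CC(C)(C)N(NC(=O)c1cccc(F)c1)C(=O)c1ccccc1Cl` gives 69.2 nM in this assay.

Within the data shown here, compound 2 stands with the lowest of the two numbers: the only measured step, a 4.8-fold lower number from compound 1 to compound 2 (0.68 log units; beyond the scatter), is the change from compound 1 to compound 2, which put a 3-fluorophenyl in place of a 2-chlorophenyl on a carbonyl carbon. Compound 3 `CC(C)(C)N(NC(=O)c1cccc(Br)c1)C(=O)c1ccccc1Cl` keeps that 3-substituted ring and the rest of compound 2 unchanged; the only difference is bromo in place of fluoro on an aromatic carbon, cut one bond further out, 3-fluorophenyl to 3-bromophenyl, on an aromatic carbon meta to a large group.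

Among the measured compounds shown here, no measured step here swaps one halogen for another on the same aromatic carbon, so the step from compound 1 to compound 2 gives only a loose guide: it shows that the ring on this carbonyl carbon matters, not how a larger halogen at this place will read. The expectation is therefore a small step in this assay, a 1.2-fold lower number from compound 2 to compound 3 (0.06 log units; within the scatter), not clearly beyond the scatter in either direction. Compound 3 is estimated at 60 nM, with a range from 20 nM to 200 nM.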

Compound 3, half-maximal effective concentration: 191 nM
Compound 3: middle estimate off by 3.2-fold (0.50 log units), on the low side, within the range that was stated.
By their numbers in this assay, from the lowest: compound 2; then compounds 3 and 1 (each within the scatter of the next).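

In this assay, the identity of the halogen at this place matters: bromo in place of fluoro, on an aromatic carbon meta to a large group, brings a 2.8-fold higher number from compound 2 to compound 3 (0.44 log units; beyond the scatter) and so separates two compounds that differ in this one atom alone. Among these compounds, compound 1 had suggested only that the ring on this carbonyl carbon counts, but the 3-bromophenyl ring in place of the 2-chlorophenyl ring brings a 1.7-fold lower number from compound 1 to compound 3 (0.24 log units; within the scatter) and leaves compound 3 not clearly separated from compound 1, so moving to this substitution place does not by itself lower the number, and compound 2 remains the lowest of the three. No measurement at hand explains why fluoro and bromo read differently here.

As far as these compounds go, with only fluoro and bromo seen at this place, it remains open whether a chloro group would read closer to compound 2 or to compound 3, and whether a non-halogen group such as methyl, methoxy or nitrile would fit at all. From the compounds shown here alone, it is also open whether the same exchange of fluoro for bromo would give a similar step on another carbon of this ring.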